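Lactam ring variants on a fused core: clearance notes

The source may hold more compounds than are shown below. What is called first, only, known or untested is meant among the compounds shown, and "the series" means these compounds.

Compound 3 `O=C1CC2(CC2)CN1c1cnc(NCc2c(F)ccc3c2CCO3)n2cnnc12` gives < 3 mL.min-1.g-1 in an ADME assay on microsomes from liver (Homo sapiens) for metabolic stability, read by LC-MS, using NADPH, with stated times of 5 min and 30 min, tested at 1 uM (on this read-out higher numbers stand for fast clearance and lower numbers for slow clearance), which is a limit of the assay rather than a number. Compound 1 `O=C1CCCN1c1cnc(NCc2c(F)ccc3c2CCO3)n2cnnc12` likewise gives a limit in this assay, < 3 mL.min-1.g-1. Compound 2 `O=C(Nc1ccccc1)c1cnc(NCc2c(F)ccc3c2CCO3)n2cnnc12` gives 14 mL.min-1.g-1 in this assay. Within the data shown here, the step that the two limits leave unreadable from compound 1 to compound 3 cannot be sized, while the step of an at least 4.6-fold lower number from compound 2 to compound 3 (0.66 log units; beyond the scatter) is the only readable one into compound 3; the limit of < 3 mL.min-1.g-1 in this assay, at which 2 of the 3 values shown sit, marks where compound 3 and compound 1 both sit.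

Compound 4 `C[C@@H]1CC(=O)N(c2cnc(NCc3c(F)ccc4c3CCO4)n3cnnc23)C1` differs from compound 3 in one place: a group of 7 heavy atoms (5 carbon, 1 nitrogen, 1 oxygen; one five-membered non-aromatic ring with 1 hetero atom) in place of a group of 8 heavy atoms (6 carbon, 1 nitrogen, 1 oxygen; one three-membered non-aromatic ring of carbon only, one five-membered non-aromatic ring with 1 hetero atom), on an aromatic carbon. Among the measured compounds shown here, no measured step bears directly on trading one small lactam for another: the nearest comparison, a step that the two limits leave unreadable from compound 1 to compound 3, is unreadable, and an at least 4.6-fold lower number from compound 2 to compound 3 (0.66 log units; beyond the scatter) concerns a different group. No step beyond the scatter is therefore expected in this assay, and compound 4 is expected to read about 2.5 mL.min-1.g-1, between 1 mL.min-1.g-1 and 6 mL.min-1.g-1, most probably reported again only as a limit. The expected step that the limit leaves unreadable from compound 3 to compound 4 is estimated to stay within the scatter.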

Compound 4, intrinsic clearance in microsomes: < 3 mL.min-1.g-1
Compound 4: no number, only a limit (the forecaster's own chance of this, stated with the estimate: 70%); the middle value is on the limit's open side.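

Methyl on a saturated ring carbon of the 2-oxopyrrolidin-1-yl group, with its one defined stereocentre, adds a third group at this position that gives only a limit in this assay, not a number: the limit of < 3 mL.min-1.g-1 in this assay, at which 3 of the 4 values shown sit.

The steps from compound 3 to compound 4 and from compound 1 to compound 4 cannot be read, as both ends of each are limits. The one readable step is an at least 4.6-fold lower number from compound 2 to compound 4 (0.66 log units; beyond the scatter), so compound 2 with its phenylcarbamoyl group remains the only compound shown with a number.

On these data alone, how the values of compound 1, compound 3 and compound 4 lie relative to one another under the limit stays open. Also open, as far as these compounds go, are the opposite configuration of the methyl-bearing carbon and whether an amine or a carboxylic acid on the same aromatic carbon would stay at the limit.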